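The compounds below may be only part of what the source reports. "The series", "measured", "known", "first", "only" and "open" are said of these compounds alone.

Working notes on the aziridine-carbonitrile urea series.

Three ureas on the shared core have been run in a functional assay on A-375 cells (Homo sapiens) for inhibition; a higher number here means a weaker inhibitor, a lower number a stronger inhibitor. Compound 1 `N#CC1CN1C(=O)Nc1ccc(Cl)cc1Cl` returns only a limit of the assay, > 39000 nM, so no number is known for it; this is the situation summed up in the limit of > 39000 nM in this assay, at which 1 of the 3 values shown sits. Compound 2 `CC(=O)c1cccc(NC(=O)N2CC2C#N)c1` gives 7900 nM, and compound 3 `N#CC1CN1C(=O)NC1CCCCC1` gives 35000 nM. Of the two numbers in hand, compound 2 therefore holds the lower one, and its gap to compound 3 lies beyond the usual scatter of repeated runs. For the measured compounds named here, no pair of measured compounds differs in a single place, so no measured step is available to lean on.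

Compound 4 `N#CC1CN1C(=O)Nc1ccccc1` is the next member to be run. Relative to compound 2 it carries hydrogen in place of acetyl on an aromatic carbon. Since the only aryl urea with a number, compound 2, is also the one that carries the acetyl, stripping that group is expected to move the number upward, by a step of a 2.5-fold higher number from compound 2 to compound 4 (0.40 log units; beyond the scatter), which would put it beyond the scatter. For compound 4 the expected value in this assay is 20000 nM, with a range of 6000 nM to 60000 nM.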

Compound 4, half-maximal inhibitory concentration: 11000 nM
Compound 4: middle estimate off by 1.8-fold (0.26 log units), on the high side; the measured number falls inside the stated range.
By their numbers in this assay, from the lowest: compounds 2 and 4 (each within the scatter of the next); then compound 3. At a limit, above all of these: compound 1.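

In this assay, for the compounds shown here, hydrogen in place of acetyl on an aromatic carbon, meta to a group of 8 heavy atoms, gives a 1.4-fold higher number from compound 2 to compound 4 (0.14 log units; within the scatter) and so provides the first measured single-place step. At this position, the number does not depend measurably on the acetyl, so the value of compound 2 can no longer be credited to that group. No measurement shown bears on why this exchange stays within the scatter.

On these data alone, whether any other group on this aromatic carbon would move the number remains open, for example an amine, a carboxylic acid or a longer chain. Compound 1 remains a limit of the assay, > 39000 nM, and offers no number to set against the others.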